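This account rests on a few compounds, and the source may have more. Where it says the series, first, only, none or still open, it means among the compounds named here.

Measured so far:
- compound 1 `N#Cc1c(O)nc(SCc2nc3ccccc3[nH]2)nc1-c1ccccc1`: 6.57 nM
- compound 2 `N#Cc1c(Nc2nccs2)nc(SCc2nc3ccccc3[nH]2)nc1-c1ccccc1`: 3.2 nM

Both values come from a functional assay on NB1 cells (Homo sapiens) for cytotoxicity, read by MTT assay, with a stated time of 3 days; a lower number here means a stronger inhibitor, a higher number a weaker inhibitor. For the measured compounds named here, compound 2 has the lower of the two numbers, and the only measured step is a 2.1-fold lower number from compound 1 to compound 2 (0.31 log units; beyond the scatter). This step is beyond the scatter but modest.

Compound 3 `N#Cc1c(NNC(N)=S)nc(SCc2nc3ccccc3[nH]2)nc1-c1ccccc1` keeps the core of compound 2 and changes one group, on a nitrogen on an aromatic ring: a group of 4 heavy atoms (1 carbon, 2 nitrogen, 1 sulfur; no ring) in place of a group of 5 heavy atoms (3 carbon, 1 nitrogen, 1 sulfur; one five-membered aromatic ring with 2 hetero atoms), on a nitrogen on an aromatic ring. The ring leaves with the 1,3-thiazol-2-yl group, and the group that enters has no ring.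

Going by the values given here, the step of a 2.1-fold lower number from compound 1 to compound 2 (0.31 log units; beyond the scatter) is the only guide, as it changes the substituent at the same place on the core. Among the compounds with values here, it shows a modest response there, but no measured compound carries a group like the one entering, so it gives no firm direction. No step beyond the scatter is therefore expected in this assay, with a slightly higher number somewhat more likely than a lower one. The expected step is a 1.6-fold higher number from compound 2 to compound 3 (0.19 log units; within the scatter). For compound 3 the estimated value is 5 nM, with an expected range of 2 nM to 12 nM.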

Compound 3, half-maximal inhibitory concentration: 5.81 nM
For compound 3 the middle estimate is 1.2-fold (0.07 log units) below the measured one; the range from low to high includes it.
By their numbers in this assay, from the lowest: compounds 2, 3 and 1 (each within the scatter of the next, the first and the last beyond it).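

In this assay, a 1.8-fold higher number from compound 2 to compound 3 (0.26 log units; within the scatter) lies within the scatter, so replacing the 1,3-thiazol-2-yl group on this nitrogen with a group of 4 heavy atoms and no ring gives no readable difference, and compound 3 shows that a value in this range does not depend on a ring at this place. a 1.1-fold lower number from compound 1 to compound 3 (0.05 log units; within the scatter) also lies within the scatter, so compound 3 cannot be told apart from either compound 1 or compound 2, even though those two are separated by a 2.1-fold lower number from compound 1 to compound 2 (0.31 log units; beyond the scatter), and the modest gain seen with the 1,3-thiazol-2-yl group therefore gives no clear ranking of the substituents at this position. No available data explain this flat response at the position.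

Still open, as far as these compounds go, is how a plain amine, a methoxy group or a morpholine ring on the same aromatic carbon would read against these closely spaced values, and whether any such group would give a step clearly beyond the scatter. Also open, from the compounds shown here alone, is whether a longer chain on this nitrogen would leave the value in this assay in the same narrow range.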